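Triazole-linked naphthoquinones: cytotoxicity in liver-derived cells

The source may report more compounds than this note shows. Statements on the series, on what has been measured and on what is new or still open speak of the compounds shown alone.

Measured so far:
Compound 1, `CC(C)=CCC1=C(OCc2cn(Cc3ccccn3)nn2)C(=O)c2ccccc2C1=O`, 658000 nM in an ADME assay on HepG2 cells (Homo sapiens) for cytotoxicity, read by MTT assay, with a stated time of 24 h; a lower number here means that less compound is tolerated, a higher number that more compound is tolerated.
Compound 2, `CC(C)=CCC1=C(OCc2cn(-c3ccc(Cl)cc3)nn2)C(=O)c2ccccc2C1=O`, 1150000 nM in this assay.

Going by the values given here, compound 2 holds the highest of the two numbers so far; its nearest neighbour is compound 1, and the difference between them, a 1.7-fold higher number from compound 1 to compound 2 (0.24 log units; within the scatter), lies within the scatter. Among the compounds with values here, in the only step measured so far, exchanging (pyridin-2-yl)methyl for 4-chlorophenyl on the aromatic nitrogen of the shared core therefore left the read-out in this assay essentially unchanged.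

Compound 3, `COc1ccc(-n2cc(COC3=C(CC=C(C)C)C(=O)c4ccccc4C3=O)nn2)c([N+](=O)[O-])c1`, is not yet measured. It differs from compound 2 as follows: 4-methoxy-2-nitrophenyl in place of 4-chlorophenyl on an aromatic nitrogen. Within the data shown here, no measured pair covers a change of this kind, so the single step from compound 1 to compound 2 is the only guide, and it was within the scatter. On that basis no step beyond the scatter is expected from compound 2 to compound 3, and the expected change is a 1.2-fold lower number from compound 2 to compound 3 (0.06 log units; within the scatter). Compound 3 is therefore estimated at 1000000 nM in this assay, with a range from 400000 nM to 2500000 nM.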

Compound 3, half-maximal cytotoxic concentration: 532000 nM
Compound 3: middle estimate off by 1.9-fold (0.27 log units), on the high side, within the range that was stated.
By their numbers in this assay, from the lowest: compounds 3, 1 and 2 (each within the scatter of the next, the first and the last beyond it).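

On the aromatic nitrogen of the shared core, the substituent can move the read-out in this assay past the scatter: 4-methoxy-2-nitrophenyl in place of 4-chlorophenyl gives a 2.2-fold lower number from compound 2 to compound 3 (0.33 log units; beyond the scatter), a modest step and the first at this position to lie beyond the scatter. The same group in place of (pyridin-2-yl)methyl gives a 1.2-fold lower number from compound 1 to compound 3 (0.09 log units; within the scatter), so compound 3 cannot be told apart from compound 1, and only the two compounds at the ends of the series are separated. The step from 4-chlorophenyl removes the chlorine and brings in a nitro and a methoxy group at once, and these three compounds do not divide its size among those changes.

No available evidence bears on what lies behind the step between compound 2 and compound 3. Also open, from the compounds shown here alone, is how a phenyl group carrying only a nitro group, only a methoxy group, or an amine or a carboxylic acid on this nitrogen would read in this assay.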